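The compounds below may be only part of what the source reports. "The series", "measured", "known", "first", "only" and "open" are said of these compounds alone.

Compound 3, with the structure `CCc1ccc(-n2cc(COC(=O)c3c(C)nc4ccc(Cl)cc4c3-c3ccccc3)nn2)cc1`, is the point of departure here, and it is looked at in an ADME assay on J774.A1 cells (Mus musculus) for cytotoxicity, read by MTT assay, with a stated time of 48 h; on this read-out lower numbers stand for higher toxicity in this test and higher numbers for lower toxicity in this test. Two compounds have given a number in this assay. Compound 1, with the structure `Cc1ccc(Cn2cc(COC(=O)c3c(C)nc4ccccc4c3-c3ccccc3)nn2)cc1`, gives 41000 nM. Compound 3 gives 99000 nM, and of the two numbers this is the higher one, with the gap to compound 1 lying beyond the usual scatter of repeated measurements. A third compound, compound 2 with the structure `Cc1nc2ccccc2c(-c2ccccc2)c1C(=O)OCc1cn(Cc2ccc(F)cc2)nn1`, was also part of this set, but in this assay compound 2 gives "not determined" (no result reported), so no number is available for it.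

Compound 4, with the structure `Cc1ccc(-n2cc(COC(=O)c3c(C)nc4ccc(Cl)cc4c3-c3ccccc3)nn2)cc1F`, has not yet been measured. It differs from compound 3 in one place: 3-fluoro-4-methylphenyl in place of 4-ethylphenyl on an aromatic nitrogen. No comparable change between two measured compounds exists in this set, so there is nothing to show how such a swap moves the number in this assay. With two groups of the same size and no donors or acceptors on either side, the expectation is that the step of a 1.1-fold lower number from compound 3 to compound 4 (0.04 log units; within the scatter) will stay within the scatter, in no clear direction. Compound 4 is therefore estimated at 90000 nM, with a range from 45000 nM to 180000 nM.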

Compound 4, half-maximal cytotoxic concentration: 34000 nM
Estimate against measurement, compound 4: 2.6-fold (0.42 log units) above; measured number below the stated range.
By their numbers in this assay, from the lowest: compounds 4 and 1 (each within the scatter of the next); then compound 3.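

In this assay, for the compounds shown here, the group on the aromatic nitrogen turns out to matter, which the earlier compounds could not show, since no two of them differed in one place only. The swap gives a 2.9-fold lower number from compound 3 to compound 4 (0.46 log units; beyond the scatter), so the compound with 3-fluoro-4-methylphenyl reads as more toxic in this test than the one with 4-ethylphenyl, even though the two groups have 8 heavy atoms each, one six-membered aromatic ring of carbon only and no hydrogen-bond donors or acceptors. Such counts therefore do not settle the outcome at this position, and no measurement at hand explains the step.

This single step changes two things at once, the ethyl becoming a methyl and a fluorine entering, so the compounds shown cannot say which of the two carries the change. They also leave open how the number would respond to a different kind of group on this phenyl ring, such as an amine, a carboxylic acid or a longer chain like butyl.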